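The source may report more compounds than this note shows. Statements on the series, on what has been measured and on what is new or still open speak of the compounds shown alone.

Measured compounds:
- compound 1, `CCNC(=O)[C@H]1O[C@@H](n2cnc3c(NC)nc(-n4cc(Cc5ccccc5)nn4)nc32)[C@H](O)[C@@H]1O`, 2.8 nM
- compound 2, `CCc1cn(-c2nc(NC)c3ncn([C@@H]4O[C@H](CO)[C@@H](O)[C@H]4O)c3n2)nn1`, 13.8 nM

Both compounds were tested in an assay on CHO cells for displacement of a labelled ligand from adenosine receptor A3 (Homo sapiens); a lower number here means a stronger inhibitor, a higher number a weaker inhibitor. Compound 1 gives the lower of the two numbers, with 2.8 nM. Compound 2 gives 13.8 nM, which is beyond the scatter of compound 1, so compound 1 is the stronger inhibitor of the pair on what has been measured.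

Compound 3, `CCNC(=O)[C@H]1O[C@@H](n2cnc3c(NC)nc(-n4cc(CC5CCCC5)nn4)nc32)[C@H](O)[C@@H]1O`, has not yet been measured. It differs from compound 1 in one place: cyclopentyl in place of phenyl on a saturated chain carbon bound to an aromatic carbon. The rest of the shared core is kept unchanged. Going by the values given here, no measured pair shows this exact change, so the direction of the step is uncertain. The expected step from compound 1 to compound 3 is a 1.8-fold higher number from compound 1 to compound 3 (0.25 log units; within the scatter), a small rise within the scatter. Compound 3 is therefore estimated at 5 nM, with a range from 1.5 nM to 18 nM.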

Compound 3, inhibition constant: 11.5 nM
Estimate against measurement, compound 3: 2.3-fold (0.36 log units) below; the measured number falls inside the stated range.
By their numbers in this assay, from the lowest: compound 1; then compounds 3 and 2 (each within the scatter of the next).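

With the rest of compound 1 kept unchanged, replacing phenyl with cyclopentyl on a saturated chain carbon bound to an aromatic carbon gives, in this assay, a 4.1-fold higher number from compound 1 to compound 3 (0.61 log units; beyond the scatter) as a modest step beyond the scatter. This position therefore responds to the ring it carries, and here the six-membered aromatic ring of carbon gives the stronger inhibitor, although compound 3 still binds at 11.5 nM without an aromatic ring in that place. No measurement at hand explains this step.

Ring size and aromatic character change together in this swap, so this one pair cannot separate their contributions. Cyclohexyl would keep the six-membered ring without aromatic character, while a pyridyl ring or an amine on the ring would show how this position responds to nitrogen.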